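The source may report more compounds than this note shows. Statements on the series, on what has been measured and on what is new or still open speak of the compounds shown alone.

Measured so far:
Compound 1 `CN(C)CCCNc1nc(-c2ccc(NC(=O)Nc3ccc(Cl)cc3Cl)cc2)nc2ccsc12`: 1020 nM
Compound 2 `CN(C)CCNc1nc(-c2ccc(NC(=O)Nc3ccc(F)cc3)cc2)nc2ccsc12`: 390 nM
Compound 3 `CN(C)CCNc1nc(-c2ccc(NC(=O)Nc3ccccc3Cl)cc2)nc2ccsc12`: 230 nM

In a functional assay on NCI-H460 cells (Homo sapiens) for cytotoxicity, read by MTT assay, with a stated time of 72 h (on this read-out lower numbers stand for stronger inhibition and higher numbers for weaker inhibition), compound 3 gives the lowest number of the three, although compound 2 sits within the usual scatter of it; only compound 1 stands clearly apart. Compound 4 `CN(C)CCNc1nc(-c2ccc(NC(=O)Nc3ccc(Cl)cc3Cl)cc2)nc2ccsc12` differs from compound 3 by chloro in place of hydrogen on an aromatic carbon. Among the compounds with values here, the one measured step between close neighbours, a 1.7-fold lower number from compound 2 to compound 3 (0.23 log units; within the scatter), swapped one halogen-bearing phenyl for another without moving the number beyond the scatter. Within the data shown here, no measured step adds a second chloro to this ring; compound 1 also carries the dichlorophenyl, but with a different chain, and offers no direct comparison. The expected step is therefore small: a 1.5-fold higher number from compound 3 to compound 4 (0.18 log units; within the scatter). Compound 4 is estimated at 350 nM, within a range from 150 nM to 800 nM.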

Compound 4, half-maximal inhibitory concentration: 1650 nM
Compound 4: middle estimate off by 4.7-fold (0.67 log units), on the low side; the whole stated range lies below it.
By their numbers in this assay, from the lowest: compounds 3 and 2 (each within the scatter of the next); then compounds 1 and 4 (each within the scatter of the next).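

Adding chloro to the 2-chlorophenyl, on the carbon para to a large group, gives a 7.2-fold higher number from compound 3 to compound 4 (0.86 log units; beyond the scatter) and so matters far more than the earlier halogen swap suggested. The 2,4-dichlorophenyl in place of 4-fluorophenyl likewise gives a 4.2-fold higher number from compound 2 to compound 4 (0.63 log units; beyond the scatter), whereas the chain difference between the two dichlorophenyl compounds gives only a 1.6-fold higher number from compound 1 to compound 4 (0.21 log units; within the scatter) and does not separate them. No available evidence explains the effect of this added chloro. As far as these compounds go, whether a methyl or methoxy group on that carbon would act like chloro remains open. So does how 4-chlorophenyl, without the 2-chloro, would compare.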